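Ethyl to 4-methoxyphenyl in a series at the limit

The source may hold more compounds than are shown below. What is called first, only, known or untested is meant among the compounds shown, and "the series" means these compounds.

Values measured in an ADME assay on HCT-116 cells (Homo sapiens) for cytotoxicity, read by CellTiter-Glo, with a stated time of 72 h (a lower number here means a stronger inhibitor, a higher number a weaker inhibitor), are these:
- Compound 1 `CC1CCN(C2CCN(S(=O)(=O)c3ccc(-c4ccccc4F)cc3)CC2)CC1` gives > 5000 nM as a limit
- Compound 2 `CC1CCN(C2CCN(S(=O)(=O)c3ccc(-c4ccc(Cl)cc4)cc3)CC2)CC1` gives > 5000 nM as a limit
- Compound 3 `CCc1ccc(S(=O)(=O)N2CCC(N3CCC(C)CC3)CC2)cc1` gives > 5000 nM as a limit

Compound 3 stands at the limit of > 5000 nM in this assay, at which 3 of the 3 values shown sit, and so offers only a limit. Compound 4 `COc1ccc(-c2ccc(S(=O)(=O)N3CCC(N4CCC(C)CC4)CC3)cc2)cc1` carries 4-methoxyphenyl in place of ethyl on an aromatic carbon, para to a large group, counted as 4-methoxyphenyl in place of ethyl on an aromatic carbon in full. The same kind of exchange runs in reverse in a step that the two limits leave unreadable from compound 1 to compound 3 and in a step that the two limits leave unreadable from compound 2 to compound 3 while a step that the two limits leave unreadable from compound 1 to compound 2 adds no size either. For the measured compounds named here, with those steps unreadable, no step of known size or direction is expected in this assay and the expected step is a step that the limit leaves unreadable from compound 3 to compound 4 on this estimate. For compound 4 the estimate is 7000 nM within an expected range of 3000 nM to 15000 nM and a limit is the likely outcome.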

Compound 4, half-maximal inhibitory concentration: > 5000 nM
Compound 4 gave a limit, no number; the forecaster's own chance of this, stated with the estimate: 85%; the middle value lies beyond the limit too.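

Compound 4 gives > 5000 nM, a limit. Its steps to compound 1, compound 2 and compound 3 cannot be read: the limit of > 5000 nM in this assay, at which 4 of the 4 values shown sit.

Still open, from the compounds shown here alone, is whether ethyl, 2-fluorophenyl, 4-chlorophenyl and 4-methoxyphenyl differ at all in this assay.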